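Notes on the ketone-side aryl change from compound 1 to compound 4

A few compounds are considered here, and "the series" means these few. Any claim that something is new, unique, unknown or untested is made for them only; others in the source may bear on it.

Three compounds of the shared core have numbers in a functional assay on RXF 393 cells (Homo sapiens) for inhibition, read by sulforhodamine B assay, with a stated time of 48 h; a lower number here means a stronger inhibitor of growth, a higher number a weaker inhibitor of growth. Compound 1 `COc1cc(-c2cc(/C=C/C(=O)c3ccc(Cl)c(Cl)c3)[nH]n2)cc(OC)c1OC` gives 2700 nM in this assay. Compound 2 `COc1ccc(-c2cc(/C=C/C(=O)c3ccc(N)cc3)[nH]n2)cc1OC` gives 2150 nM, and compound 3 `COc1ccc(-c2cc(/C=C/C(=O)c3cc(OC)c(OC)c(OC)c3)[nH]n2)cc1OC` gives 1530 nM. Compound 1 holds the highest of the three numbers, but its gaps to compound 2 and to compound 3 both lie within the scatter of repeated measurements, so no order among the three can be read from these values.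

Compound 4 `COc1ccc(C(=O)/C=C/c2cc(-c3cc(OC)c(OC)c(OC)c3)n[nH]2)cc1OC` has not yet been measured in this assay. It differs from compound 1 in one place: 3,4-dimethoxyphenyl in place of 3,4-dichlorophenyl on a carbonyl carbon. The rest of the core of compound 1 is kept unchanged.

Among the measured compounds shown here, no pair of measured compounds differs in only one place, so no measured step of the same kind is available for comparison. The three measured compounds, which differ among themselves in more than one place, all sit within the scatter of one another. On that basis the step from compound 1 to compound 4 is expected to be small, a 1.4-fold lower number from compound 1 to compound 4 (0.13 log units; within the scatter), with no change beyond the scatter in either direction. Compound 4 is therefore expected to give about 2000 nM in this assay, with a range from 900 nM to 4500 nM.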

Compound 4, concentration for 50% growth inhibition: 1350 nM
The estimate for compound 4 lay 1.5-fold (0.17 log units) above the measured number; measured number inside the range.
By their numbers in this assay, from the lowest: compounds 4, 3, 2 and 1 (each within the scatter of the next).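

In this assay, among the compounds shown here, the exchange of 3,4-dichlorophenyl for 3,4-dimethoxyphenyl on a carbonyl carbon is the first single-place step available, and it gives a 2.0-fold lower number from compound 1 to compound 4 (0.30 log units; within the scatter). Within this one pair, a group with no hydrogen-bond acceptors and a group that has them therefore give numbers that cannot be told apart, so the position accepts either group and no gain or loss can be assigned to the change. No measurement of a property of these groups bears on this result.

One pair cannot show whether other groups on this carbonyl carbon would move the number beyond the scatter, and a smaller unsubstituted phenyl, a ring bearing a carboxylic acid or a ring bearing a longer alkoxy chain would test how far this tolerance extends. Going by these compounds, it also remains open whether the same exchange of 3,4-dichlorophenyl for 3,4-dimethoxyphenyl would give a comparable step if the rest of the core of compound 1 were changed elsewhere.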